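Compound 2 to compound 4: ethyl for ethoxy

The source may hold more compounds than are shown below. What is called first, only, known or untested is meant among the compounds shown, and "the series" means these compounds.

For the measured compounds named here, in an in vitro ADME assay on microsomes from liver (Homo sapiens) for metabolic stability (on this read-out lower numbers stand for slow clearance and higher numbers for fast clearance), compound 2 (`CCOc1nc2nc(C)cc(Nc3ccc(C(F)(F)F)cc3)n2n1`) gives 7 mL.min-1.g-1, the only true number in the set so far. Compound 1 (`Cc1cc(Nc2ccc(S(F)(F)(F)(F)F)cc2)n2nc(C(F)(F)F)nc2n1`) reads < 5 mL.min-1.g-1, which is a limit of the assay. Compound 3 (`Cc1cc(Nc2ccc(S(F)(F)(F)(F)F)cc2)n2nc(C(C)(F)F)nc2n1`) reads < 5 mL.min-1.g-1, also a limit. The next change leads to compound 4 (`CCc1nc2nc(C)cc(Nc3ccc(C(F)(F)F)cc3)n2n1`): ethyl in place of ethoxy on an aromatic carbon. Going by the values given here, the one measured step is a step that the two limits leave unreadable from compound 1 to compound 3, so it lends no size to carry over. With compound 2 at 7 mL.min-1.g-1 as the only anchor, no step beyond the scatter is expected in this assay, in either direction. The expected step is no change at the digits printed from compound 2 to compound 4 (within the scatter). Compound 4 is estimated at 7 mL.min-1.g-1, with an expected range of 5 mL.min-1.g-1 to 14 mL.min-1.g-1.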

Compound 4, intrinsic clearance in microsomes: < 5 mL.min-1.g-1
Compound 4 was reported as a limit; the forecaster's own chance of this, stated with the estimate: 25%; at least 1.4-fold (0.14 log units) between middle value and limit.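

In this assay, ethyl in place of ethoxy on an aromatic carbon gives an at least 1.4-fold lower number from compound 2 to compound 4 (0.14 log units; that floor lies within the scatter). For the compounds shown here, this is the only readable step, and it shows that losing the ethoxy oxygen at this position does not raise the reading. Compound 4 is reported as a limit, so the full size of the step stays hidden: the limit of < 5 mL.min-1.g-1 in this assay, at which 3 of the 4 values shown sit.

From the compounds shown here alone, how far compound 4 lies under its limit stays open. Also open, going by these compounds, is whether an amine or a longer chain such as propyl on this aromatic carbon would keep the reading at that limit.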